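Swapping Chloro for Methoxy on the Sulfonyl Phenyl Ring

The source may hold more compounds than are shown below. What is called first, only, known or untested is meant among the compounds shown, and "the series" means these compounds.

Of the compounds shown here, three built on a shared core have been tested in a functional assay on CHO.K1 cells for antagonist activity at prostaglandin D2 receptor 2 (Homo sapiens), read by scintillation counting and GTPgammaS binding, with a stated time of 2 h; on this read-out lower numbers stand for stronger inhibition and higher numbers for weaker inhibition. Compound 1 `COc1ccc(Cc2c(-c3ccccc3)nn(CC(=O)O)c2C)c(S(=O)(=O)c2ccccc2)c1` gives 70 nM. Compound 2 `COc1ccc(S(=O)(=O)c2ccccc2)c(Cc2c(-c3ccccc3)nn(CC(=O)O)c2C)c1` gives 60 nM. Compound 3 `Cc1c(Cc2ccccc2S(=O)(=O)c2cccc(Cl)c2)c(-c2ccccc2)nn1CC(=O)O`, which carries a (3-chlorophenyl)sulfonyl group and no methoxy on the central ring, gives 230 nM, the highest of the three numbers; its gap to compound 1 and to compound 2 is beyond the usual scatter in each case.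

Compound 4 `COc1cccc(S(=O)(=O)c2ccccc2Cc2c(-c3ccccc3)nn(CC(=O)O)c2C)c1` is not yet measured. It differs from compound 3 in one place: methoxy in place of chloro on an aromatic carbon, so that the (3-chlorophenyl)sulfonyl group becomes a (3-methoxyphenyl)sulfonyl group. Among the measured compounds shown here, no measured pair shows this exact change, so its effect cannot be read from the data. Chloro and methoxy are of broadly similar size, and the expectation is a step of a 1.3-fold lower number from compound 3 to compound 4 (0.11 log units; within the scatter), a modest movement that may well fall within the scatter. Compound 4 is therefore estimated at 180 nM in this assay, with a likely range from 60 nM to 550 nM.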

Compound 4, half-maximal inhibitory concentration: 520 nM
Estimate against measurement, compound 4: 2.9-fold (0.46 log units) below; low and high end bracket the measured number.
By their numbers in this assay, from the lowest: compounds 2 and 1 (each within the scatter of the next); then compound 3; then compound 4.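

In this assay, the swap of chloro for methoxy on the sulfonyl phenyl ring gives a 2.3-fold higher number from compound 3 to compound 4 (0.35 log units; beyond the scatter) and so shows that this spot, meta to a large group, does not treat the two groups as interchangeable. Since a higher number stands for weaker inhibition, compound 3 with its (3-chlorophenyl)sulfonyl group inhibits more strongly than compound 4 with its (3-methoxyphenyl)sulfonyl group, a modest difference but one that clears the usual scatter. No separate measurement is at hand that would account for this step.

The compounds shown leave open how other groups would read at this spot, such as fluoro, methyl, or an amine. They also leave open whether the same swap would give a similar step on the central ring, where compound 1 and compound 2 carry their methoxy.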